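The source may hold more compounds than are shown below. What is called first, only, known or untested is meant among the compounds shown, and "the series" means these compounds.

Compound 1, `CC1CCC(=O)N1CC#CCn1ccnc1`, is the starting point of this small set. In a functional assay on the whole organism for antagonist activity, with Mus musculus as the target (on this read-out lower numbers stand for an effect already at smaller amounts and higher numbers for an effect only at larger amounts of compound), compound 1 gives 0.54 mg/kg. Compound 2, `Cc1cncn1CC#CCN1C(=O)CCC1C`, carries one change relative to compound 1: methyl in place of hydrogen on an aromatic carbon. In this assay compound 2 gives 0.8 mg/kg, and the step of a 1.5-fold higher number from compound 1 to compound 2 (0.17 log units; within the scatter) is the only measured instance of this change among the compounds shown.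

Compound 3, `CN(C)C(=O)N(C)CC#CCn1ccnc1`, rests on a different core; the difference between the two cores is not broken down here. In this assay compound 3 gives 11.8 mg/kg, the highest of the three numbers, and its gap to compound 2 and to compound 1 lies beyond the scatter in both cases.

Compound 4, `Cc1cncn1CC#CCN(C)C(=O)N(C)C`, has not yet been measured. It differs from compound 3 by methyl in place of hydrogen on an aromatic carbon, the same change that separates compound 1 and compound 2. The expectation for the step of a 1.4-fold higher number from compound 3 to compound 4 (0.16 log units; within the scatter) rests on compound 1 and compound 2, where the step was a 1.5-fold higher number from compound 1 to compound 2 (0.17 log units; within the scatter), within the scatter. From the compounds shown here alone, whether the same change carries over to the core of compound 3 is unknown, so the range is kept wide. Compound 4 is therefore expected to give about 17 mg/kg in this assay, between 7 mg/kg and 40 mg/kg.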

Compound 4, dose for half-maximal effect: 9.7 mg/kg
Compound 4: the middle estimate sits 1.8-fold (0.24 log units) above what was measured; the measured number falls inside the stated range.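

In this assay, methyl in place of hydrogen on an aromatic carbon of the core of compound 3 gives a 1.2-fold lower number from compound 3 to compound 4 (0.09 log units; within the scatter). Set beside the earlier instance of this change, the new step does not stand apart from it: the same change on two cores in this assay, a 1.5-fold higher number (0.17 log units; within the scatter) from compound 1 to compound 2 and a 1.2-fold lower number (0.09 log units; within the scatter) from compound 3 to compound 4, 1.8-fold (0.26 log units) apart, within the scatter of two such steps. On the two cores shown, the change therefore leaves the number within the scatter each time, but two pairs cannot show that this would hold on a further core, and neither step supports a real rise or fall in the number.

The compounds shown leave open whether a larger group in the same place, such as an ethyl chain, a chlorine atom or a carboxylic acid, would move the number beyond the scatter on either core. They also leave open whether methyl on another carbon of the five-membered aromatic ring would behave as it does here.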